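The source may report more compounds than this note shows. Statements on the series, on what has been measured and on what is new or still open speak of the compounds shown alone.

In an assay on CHO cells for displacement of a labelled ligand from prostaglandin E2 receptor EP3 subtype (Homo sapiens), read by radioligand binding (on this read-out higher numbers stand for weaker inhibition and lower numbers for stronger inhibition), compound 3 `CC(C)C(Cc1noc(=O)[nH]1)c1ccc(-c2ccc3cccc(F)c3c2)[nH]c1=O` gives 34 nM. Against compound 1 `CC(C)C(c1ccc(-c2ccc3cccc(F)c3c2)[nH]c1=O)N1CCCCS1(=O)=O`, which gives 14 nM, the step is a 2.4-fold higher number from compound 1 to compound 3 (0.39 log units; beyond the scatter). Against compound 2 `CC(C)C(c1ncco1)c1ccc(-c2ccc3cccc(F)c3c2)[nH]c1=O`, which gives 24 nM, the two numbers lie within the scatter of each other a 1.4-fold higher number from compound 2 to compound 3 (0.15 log units; within the scatter). Compound 4 `CC(C)C(Cc1nnn[nH]1)c1ccc(-c2ccc3cccc(F)c3c2)[nH]c1=O` differs from compound 3 by a group of 5 heavy atoms (1 carbon, 4 nitrogen; one five-membered aromatic ring with 4 hetero atoms) in place of a group of 6 heavy atoms (2 carbon, 2 nitrogen, 2 oxygen; one five-membered aromatic ring with 3 hetero atoms), on a saturated chain carbon, two bonds along the chain from an aromatic carbon. The measured steps that bear on this are the exchanges of the group on the same saturated chain carbon: a 1.7-fold higher number from compound 1 to compound 2 (0.23 log units; within the scatter), a 2.4-fold higher number from compound 1 to compound 3 (0.39 log units; beyond the scatter) and a 1.4-fold higher number from compound 2 to compound 3 (0.15 log units; within the scatter), all small, at most modest. Another exchange of a five-membered aromatic ring at this place is therefore expected to give no step beyond the scatter in this assay, and compound 4 is estimated at 40 nM, with a range from 15 nM to 110 nM, the expected step being a 1.2-fold higher number from compound 3 to compound 4 (0.07 log units; within the scatter).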

Compound 4, inhibition constant: 34 nM
For compound 4 the middle estimate is 1.2-fold (0.07 log units) above the measured one; the range from low to high includes it.
By their numbers in this assay, from the lowest: compounds 1, 2, 3 and 4 (each within the scatter of the next, the first and the last beyond it).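

In this assay the 1H-tetrazol-5-yl group on this saturated chain carbon, two bonds along the chain from an aromatic carbon, stands level with the ring it replaces, with no change at the digits printed from compound 3 to compound 4 (within the scatter) and with a 1.4-fold higher number from compound 2 to compound 4 (0.15 log units; within the scatter) as well. The modest gap to the six-membered ring of compound 1 remains, with a 2.4-fold higher number from compound 1 to compound 4 (0.39 log units; beyond the scatter) at the same size as for compound 3. Nothing available explains why this exchange leaves the read-out unmoved. On these data alone, whether a carboxylic acid, an amine or a longer chain at this place would stay in the same range remains open. The compounds shown also leave open how this exchange behaves at any other receptor.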